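A few compounds are considered here, and "the series" means these few. Any claim that something is new, unique, unknown or untested is made for them only; others in the source may bear on it.

Compound 1 `Cc1ccc(Nc2ncc3c(n2)N(C)C(=O)N(c2cc(NC(=O)c4cccc(C(F)(F)F)c4)ccc2C)C3)cc1` and compound 2 `Cc1ccc(Nc2ncc3c(n2)N(C)C(=O)N(c2cc(NC(=O)c4cccc(C(F)(F)F)c4)ccc2C)C3)cc1N(C)C` share one core, while compound 3 `Cc1ccc(NC(=O)c2cccc(C(F)(F)F)c2)cc1NC(=O)c1cnc(Nc2ccc(C)c([N+](=O)[O-])c2)nc1N(C)C` is built on another; the difference between the two cores is not broken down here. In a functional assay on K562 cells (Homo sapiens) for antiproliferative activity, read by CellTiter-Glo and CCK-8 assay, with a stated time of 72 h (on this read-out lower numbers stand for stronger inhibition of growth and higher numbers for weaker inhibition of growth), compound 1 gives 18 nM and compound 2 gives 28 nM. Compound 3 reaches only the limit of the assay, > 10000 nM, which is not a number. Between compound 2 and compound 1 the change is hydrogen in place of dimethylamino on an aromatic carbon, and the step is a 1.6-fold lower number from compound 2 to compound 1 (0.19 log units; within the scatter). Compound 4 `Cc1ccc(NC(=O)c2cccc(C(F)(F)F)c2)cc1NC(=O)c1cnc(Nc2ccc(C)c([N+](=O)[O-])c2)nc1`, not yet measured, differs from compound 3 by hydrogen in place of dimethylamino on an aromatic carbon, the same kind of change, though here it sits on a six-membered aromatic ring with 2 nitrogen, next to the ring nitrogen, ortho to a large group and meta to a (4-methyl-3-nitrophenyl)amino group, rather than on a ring of carbon only, ortho to a methyl group. Compound 3 sits at the limit of > 10000 nM in this assay, at which 1 of the 3 values shown sits, and the measured step of this kind was within the scatter. On that rests the expectation of a step of a number no higher from compound 3 to compound 4 (the limit leaves the size open). Compound 4 is therefore estimated at 10000 nM, most likely again reported only as a limit.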

Compound 4, concentration for 50% growth inhibition: 380 nM
For compound 4 the middle estimate is 26-fold (1.42 log units) above the measured one, and the stated range ends above it.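

On the core of compound 3, in this assay, hydrogen in place of dimethylamino gives an at least 26-fold lower number from compound 3 to compound 4 (1.42 log units; beyond the scatter). This change therefore does not carry over at a single size between the two cores in this series: the same change on two cores in this assay, a 1.6-fold lower number (0.19 log units; within the scatter) from compound 2 to compound 1 and an at least 26-fold lower number (1.42 log units; beyond the scatter) from compound 3 to compound 4, at least 16-fold (1.22 log units) apart, beyond the scatter of two such steps. Two pairs do not show which feature of the cores sets this gap, nor how large the step on the core of compound 3 really is, as compound 3 stands only at a limit and not at a number: the limit of > 10000 nM in this assay, at which 1 of the 4 values shown sits.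

The compounds shown leave open how a group other than hydrogen or dimethylamino at this place, such as methylamino, methoxy or morpholine, would read out on either core. They also leave open whether the two cores would part in the same way if the trifluoromethyl group were replaced by another group, for example a chlorine atom or a nitrile.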